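A few compounds are considered here, and "the series" means these few. Any claim that something is new, unique, unknown or untested is made for them only; others in the source may bear on it.

Compound 1 `N#Cc1cccc(-n2cc(COc3cccc(NC(=O)Nc4ccc(Cl)c(C(F)(F)F)c4)c3)nn2)c1` is a diaryl urea bearing a 3-cyanophenyl group on an aromatic nitrogen of its triazole-containing core. In a functional assay on HepG2 cells (Homo sapiens) for inhibition, read by MTT assay, with a stated time of 72 h (on this read-out higher numbers stand for weaker inhibition and lower numbers for stronger inhibition), compound 1 gives 2760 nM. Its nearest companion is compound 2 `N#Cc1ccc(-n2cc(COc3cccc(NC(=O)Nc4ccc(Cl)c(C(F)(F)F)c4)c3)nn2)cc1`, which in this assay gives 2980 nM, so that the step of a 1.1-fold higher number from compound 1 to compound 2 (0.03 log units; within the scatter). Its furthest companion is compound 3 `CC(C)c1ccccc1-n1cc(COc2cccc(NC(=O)Nc3ccc(Cl)c(C(F)(F)F)c3)c2)nn1`, which gives 1900 nM in this assay; the step of a 1.5-fold lower number from compound 1 to compound 3 (0.16 log units; within the scatter). Between the other two compounds the step of a 1.6-fold lower number from compound 2 to compound 3 (0.20 log units; within the scatter). All three numbers therefore sit close together, and compound 1 stands among them without separating from either.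

Compound 4 `O=C(Nc1cccc(OCc2cn(-c3ccc(C(F)(F)F)cc3)nn2)c1)Nc1ccc(Cl)c(C(F)(F)F)c1` differs from compound 1 in one place: 4-(trifluoromethyl)phenyl in place of 3-cyanophenyl on an aromatic nitrogen. Every measured step that changes the group on this aromatic nitrogen stayed inside the scatter, whether a nitrile moved from one position to another or a 2-isopropylphenyl group replaced a cyanophenyl. Within the data shown here, the exchange for 4-(trifluoromethyl)phenyl is another change at the same position, and nothing among the measured steps points to a direction. Compound 4 is therefore expected to give 2400 nM in this assay, with a range from 1200 nM to 4800 nM, which means an expected step of a 1.2-fold lower number from compound 1 to compound 4 (0.06 log units; within the scatter) that stays within the scatter.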

Compound 4, half-maximal inhibitory concentration: 1800 nM
For compound 4 the middle estimate is 1.3-fold (0.12 log units) above the measured one, and the stated range covers the measured number.
By their numbers in this assay, from the lowest: compounds 4, 3, 1 and 2 (each within the scatter of the next).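

In this assay, the new group keeps the number inside the scatter, as a 1.5-fold lower number from compound 1 to compound 4 (0.19 log units; within the scatter) shows, and the most direct comparison, trifluoromethyl for cyano on the same aromatic carbon, gives a 1.7-fold lower number from compound 2 to compound 4 (0.22 log units; within the scatter). Among these compounds, the step to the only compound with an alkyl group on its phenyl ring, a 1.1-fold lower number from compound 3 to compound 4 (0.02 log units; within the scatter), also stays inside the scatter, so four differently substituted phenyl groups on this aromatic nitrogen now give numbers that cannot be told apart. Compound 4 adds something the earlier steps did not show: a trifluoromethyl group, with its fluorine atoms and no hydrogen-bond acceptor, can stand where the nitrile stood without the number leaving the scatter, although nothing available explains why these values stay so close.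

All four compounds carry a substituted phenyl ring on this nitrogen, so the result says nothing about a group without that ring, such as a simple butyl chain, or about a phenyl ring bearing an amine or a carboxylic acid. From the compounds shown here alone, whether any such group would move the number beyond the scatter remains open.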